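The source may hold more compounds than are shown below. What is called first, only, known or untested is meant among the compounds shown, and "the series" means these compounds.

Of the compounds shown here, three built on a shared core have been tested in a functional assay on the whole organism for inhibition, with Mus musculus as the target; on this read-out higher numbers stand for an effect only at larger amounts of compound and lower numbers for an effect already at smaller amounts. Compound 3 `CCN1CCCC1CNC(=O)c1cc(NS(=O)(=O)N(C)C)c(C)cc1OC` gives 13.3 mg/kg in this assay, the highest of the two numbers reported. Compound 1 `CCN1CCCC1CNC(=O)c1cc(N(C)S(C)(=O)=O)c(Cl)cc1OC` gives 7.7 mg/kg in this assay, and the gap between compound 3 and compound 1 lies within the usual scatter. For compound 2 `CCN1CCCC1CNC(=O)c1cc(NS(=O)(=O)N(C)C)ccc1OC` this assay returns only a limit, > 50 mg/kg, rather than a number. Within the data shown here, the single step that changes one place runs an at least 3.7-fold lower number from compound 2 to compound 3 (0.57 log units; beyond the scatter), a methyl in place of hydrogen on an aromatic carbon. Compound 4 `CCN1CCCC1CNC(=O)c1cc(NS(=O)(=O)N(C)C)c(Cl)cc1OC` has not yet been measured; it differs from compound 3 by chloro in place of methyl on an aromatic carbon. Among the measured compounds shown here, no measured step swaps methyl for chloro, so the step from compound 2 to compound 3 bears on it only by showing that a group at this carbon is tolerated, while compound 1, which also carries a chloro group, gives 7.7 mg/kg. Compound 4 is therefore expected to give about 9 mg/kg, within a range from 4 mg/kg to 20 mg/kg. The expected step of a 1.5-fold lower number from compound 3 to compound 4 (0.17 log units; within the scatter) is estimated to stay within the scatter.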

Compound 4, dose for half-maximal effect: 8.3 mg/kg
Estimate against measurement, compound 4: 1.1-fold (0.04 log units) above; the range from low to high includes it.
By their numbers in this assay, from the lowest: compounds 1, 4 and 3 (each within the scatter of the next). At a limit, above all of these: compound 2.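

In this assay, methyl and chloro on this aromatic carbon cannot be told apart, since a 1.6-fold lower number from compound 3 to compound 4 (0.20 log units; within the scatter) stays within the scatter. Chloro in place of hydrogen gives an at least 6.0-fold lower number from compound 2 to compound 4 (0.77 log units; beyond the scatter), so two different groups now show a step beyond the scatter, and its size is only a minimum, as compound 2 stands at a limit and not at a number: the limit of > 50 mg/kg in this assay, at which 1 of the 4 values shown sits. With chloro held fixed, (dimethylsulfamoyl)amino in place of methyl(methylsulfonyl)amino gives a 1.1-fold higher number from compound 1 to compound 4 (0.03 log units; within the scatter), so this swap shows no difference beyond the scatter.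

On these data alone, it remains open whether other groups on this carbon, such as fluoro, methoxy, an amine or a longer chain, would match methyl and chloro. These compounds also cannot tell what methyl and chloro share that matters here.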